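Swapping Fluorophenyl for Pyridinyl: Expecting Another Inactive Compound

The source may report more compounds than this note shows. Statements on the series, on what has been measured and on what is new or still open speak of the compounds shown alone.

Compound 1 `Cc1c(O)ccc2c1[C@H](Cn1cc(-c3ccc(F)cc3)nn1)[C@@]13CC(=O)[C@@](C)(CC[C@@H]21)C3` — > 20000 nM
Compound 2 `Cc1c(O)ccc2c1[C@H](Cn1cc(-c3ccccn3)nn1)[C@@]13CC(=O)[C@@](C)(CC[C@@H]21)C3` — > 20000 nM
Compound 3 `C=C1C[C@]23C[C@@]1(O)CC[C@H]2c1cc(Br)c(O)c(C)c1[C@@H]3Cn1cc(-c2ccc(F)cc2)nn1` — > 20000 nM

In a functional assay on SMMC-7721 cells (Homo sapiens) for cytotoxicity, read by MTT assay, with a stated time of 4 days (on this read-out lower numbers stand for stronger inhibition and higher numbers for weaker inhibition), compound 1 gives only a limit, > 20000 nM. Compound 2 likewise gives only a limit, > 20000 nM. The change between them is pyridin-2-yl in place of 4-fluorophenyl on an aromatic carbon, and the step that the two limits leave unreadable from compound 1 to compound 2 cannot be sized, since both values sit at the limit. Compound 3 also gives only a limit, > 20000 nM. How the core of compound 3 differs from that of compound 1 is not broken down here.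

Compound 4 `C=C1C[C@]23C[C@@]1(O)CC[C@H]2c1cc(Br)c(O)c(C)c1[C@@H]3Cn1cc(-c2ccccn2)nn1` is not yet measured; it arises from compound 3 by the same change, (pyridin-2-yl in place of 4-fluorophenyl on an aromatic carbon). Because the limit of > 20000 nM in this assay, at which 3 of the 3 values shown sit, holds for every value shown, the step from compound 3 to compound 4 is expected to be a step that the limit leaves unreadable from compound 3 to compound 4. Compound 4 is therefore estimated at 30000 nM, within 12000 nM to 100000 nM, most likely reported again only as a limit.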

Compound 4, half-maximal inhibitory concentration: > 20000 nM
Compound 4 was reported as a limit; the forecaster's own chance of this, stated with the estimate: 85%; the middle value does not contradict the limit.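

Among the compounds shown here, compound 3 and compound 4 both give only limits in this assay, so no step between them can be read. Going by these compounds, whether 4-fluorophenyl or pyridin-2-yl gives stronger inhibition, on either core, remains open.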